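Adding a 3-methoxyphenyl group to compound 2

A few compounds are considered here, and "the series" means these few. Any claim that something is new, unique, unknown or untested is made for them only; others in the source may bear on it.

In a functional assay on HCT-116 cells (Homo sapiens) for antiproliferative activity, read by MTT assay, with a stated time of 72 h (on this read-out higher numbers stand for weaker inhibition and lower numbers for stronger inhibition), compound 1 `CCNC(=O)CCc1cccc2c1B(O)OC2` gives > 100000 nM which is a limit of the assay and not a number. Among the compounds with values here, compound 2 `O=C(CCc1cccc2c1C(O)OC2)Nc1ccccc1` gives 22000 nM and so holds the only actual number so far. Compound 3 `COc1cccc(-c2cccc(NC(=O)CCc3cccc4c3C(O)OC4)c2)c1` differs from compound 2 by 3-methoxyphenyl in place of hydrogen on an aromatic carbon with 3-methoxyphenyl in place of hydrogen on an aromatic carbon, meta to a large group. Within the data shown here, no step between measured compounds is available as a guide. The expected change is a 3.1-fold lower number from compound 2 to compound 3 (0.50 log units; beyond the scatter) as a moderate gain in inhibition beyond the usual scatter. In this assay compound 3 is estimated at 7000 nM with a range of 2000 nM to 25000 nM expected around it.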

Compound 3, half-maximal inhibitory concentration: 49000 nM
The estimate for compound 3 lay 7.0-fold (0.85 log units) below the measured number; measured number above the stated range.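

In this assay, placing 3-methoxyphenyl on an aromatic carbon, meta to a large group, gives a 2.2-fold higher number from compound 2 to compound 3 (0.35 log units; beyond the scatter). Within the data shown here, this is the first step that can be read between measured compounds, and it shows that adding this group here weakens inhibition rather than strengthening it. Compound 1 is a limit of the assay and not a number, so it provides no step: the limit of > 100000 nM in this assay, at which 1 of the 3 values shown sits.

As far as these compounds go, whether the loss comes from the added ring or from its methoxy group remains open. So does how a plain phenyl, an amine or a carboxylic acid at this position would read.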